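Fluoro step transferred across two related cores

The source may hold more compounds than are shown below. What is called first, only, known or untested is meant among the compounds shown, and "the series" means these compounds.

Compound 1 `Cn1ccc2c(Oc3ccc(NC(=O)c4cn(-c5ccc(Br)cc5)c5ccccc5c4=O)cc3F)ccnc21` gives 1830 nM in a functional assay on MCF7 cells (Homo sapiens) for inhibition, read by MTT assay, with a stated time of 72 h; a lower number here means a stronger inhibitor, a higher number a weaker inhibitor. Compound 2 `Cn1ccc2c(Oc3ccc(NC(=O)c4cn(-c5ccc(Br)cc5F)c5ccccc5c4=O)cc3F)ccnc21` carries the difference fluoro in place of hydrogen on an aromatic carbon and in this assay compound 2 gives 420 nM, a step of a 4.4-fold lower number from compound 1 to compound 2 (0.64 log units; beyond the scatter). Compound 3 `O=C(Nc1ccc(Oc2ccnc3[nH]ccc23)c(F)c1)c1cn(-c2ccc(Br)cc2)c2ccccc2c1=O` differs from compound 1 by hydrogen in place of methyl on an aromatic nitrogen; in this assay compound 3 gives 650 nM, a step of a 2.8-fold lower number from compound 1 to compound 3 (0.45 log units; beyond the scatter). The values of compound 2 and compound 3 lie within the scatter of each other. Compound 4 `O=C(Nc1ccc(Oc2ccnc3[nH]ccc23)c(F)c1)c1cn(-c2ccc(Br)cc2F)c2ccccc2c1=O` differs from compound 3 by fluoro in place of hydrogen on an aromatic carbon. The place of entry is described in the same words for both pairs, so the change is the same one that moved compound 1 to compound 2, and it is expected to carry over in this assay as roughly a 3.8-fold lower number from compound 3 to compound 4 (0.58 log units; beyond the scatter), resting on the size of the step of a 4.4-fold lower number from compound 1 to compound 2 (0.64 log units; beyond the scatter) applied to compound 3 at 650 nM. Compound 4 is therefore estimated at 170 nM, with a plausible range from 70 nM to 450 nM.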

Compound 4, half-maximal inhibitory concentration: 1390 nM
Beside the measured number, compound 4's estimate is 8.2-fold (0.91 log units) below it, and the stated range ends below it.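

In this assay the change from 4-bromophenyl to 4-bromo-2-fluorophenyl gives a 2.1-fold higher number from compound 3 to compound 4 (0.33 log units; beyond the scatter), so on the core of compound 3 it reverses direction relative to the core of compound 1: the same change on two cores in this assay, a 4.4-fold lower number (0.64 log units; beyond the scatter) from compound 1 to compound 2 and a 2.1-fold higher number (0.33 log units; beyond the scatter) from compound 3 to compound 4, 9.3-fold (0.97 log units) apart, beyond the scatter of two such steps

Hydrogen in place of methyl on the aromatic nitrogen gives a 3.3-fold higher number from compound 2 to compound 4 (0.52 log units; beyond the scatter), so that step also depends on the other change: the same change on two cores in this assay, a 2.8-fold lower number (0.45 log units; beyond the scatter) from compound 1 to compound 3 and a 3.3-fold higher number (0.52 log units; beyond the scatter) from compound 2 to compound 4, 9.3-fold (0.97 log units) apart, beyond the scatter of two such steps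

Across these four compounds the two changes do not add, and neither step can be carried from one core to another; the data do not show what lies behind this reversal, or whether it extends beyond these compounds.

Still open, from the compounds shown here alone, is whether chloro or methoxy on the same aromatic carbon would follow fluoro on each core. Also open, going by these compounds, is how an ethyl group on the aromatic nitrogen would behave.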